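The source may report more compounds than this note shows. Statements on the series, on what has been measured and on what is new or still open speak of the compounds shown alone.

In a physicochemical assay for solubility (on this read-out higher numbers stand for higher solubility and lower numbers for lower solubility), compound 1 `CC1CCCN(c2c(C#N)c(C(F)F)nn2-c2ccc(S(C)(=O)=O)cc2)C1` gives 50 ug/mL. Compound 2 `CS(=O)(=O)c1ccc(-n2nc(C(F)F)c(C#N)c2NCC2CC2)cc1` gives > 200 ug/mL, which is a limit of the assay and not a number. Compound 3 `CC(C)(C)CNc1c(C#N)c(C(F)F)nn1-c1ccc(S(C)(=O)=O)cc1` carries tert-butyl in place of cyclopropyl on a saturated chain carbon bound to a nitrogen on an aromatic ring. Going by the values given here, the one measured step that bears on this, an at least 4.0-fold higher number from compound 1 to compound 2 (0.60 log units; beyond the scatter), changed the amine on an aromatic carbon, and its full size remains open. On that step alone, a modest fall in this assay is expected, an at least 1.6-fold lower number from compound 2 to compound 3 (0.22 log units; that floor lies within the scatter). Compound 3 is estimated at 120 ug/mL, within an expected range of 40 ug/mL to 300 ug/mL.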

Compound 3, solubility: > 200 ug/mL
Compound 3 ended at the assay's limit; the forecaster's own chance of this, stated with the estimate: 35%; middle value at least 1.6-fold (0.22 log units) away from the limit.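

With neopentylamino in place of 3-methylpiperidin-1-yl on an aromatic carbon, this assay shows an at least 4.0-fold higher number from compound 1 to compound 3 (0.60 log units; beyond the scatter). The higher number seen from compound 1 therefore holds with tert-butyl as well as with cyclopropyl at this saturated chain carbon, so it does not depend on the three-membered ring. The step between compound 2 and compound 3 cannot be read, since both values are limits of the assay and not numbers: the limit of > 200 ug/mL in this assay, at which 2 of the 3 values shown sit.

On these data alone, how far compound 2 and compound 3 each lie past that limit stays open. Also open, as far as these compounds go, is how a hydroxyl or a carboxylic acid at this place would read.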